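Iodo for Isopropyl in a Series of Antiproliferative Compounds

The compounds below may be only part of what the source reports. "The series", "measured", "known", "first", "only" and "open" are said of these compounds alone.

The measurements in a functional assay on HT-29 cells (Homo sapiens) for antiproliferative activity, read by sulforhodamine B assay, with a stated time of 48 h (a higher number here means a weaker inhibitor, a lower number a stronger inhibitor), are these:

compound 1, `CCCCCC(=O)Nc1ccc(S(=O)(=O)Oc2ccccc2C(C)C)cc1`: 6400 nM
compound 2, `CCCCCC(=O)Nc1ccc(S(=O)(=O)Oc2ccccc2I)cc1`: 13000 nM
compound 3, `CCCCCNC(=O)Nc1ccc(S(=O)(=O)Oc2ccccc2C(C)C)cc1`: 4900 nM

In this assay compound 1 and compound 3 give numbers within the scatter of each other, the step being a 1.3-fold lower number from compound 1 to compound 3 (0.12 log units; within the scatter). The cores of compound 1 and compound 3 differ by pentylamino in place of pentyl on a carbonyl carbon. The change iodo in place of isopropyl on an aromatic carbon produced a 2.0-fold higher number from compound 1 to compound 2 (0.31 log units; beyond the scatter). Compound 4, `CCCCCNC(=O)Nc1ccc(S(=O)(=O)Oc2ccccc2I)cc1`, has not been measured; it differs from compound 3 by iodo in place of isopropyl on an aromatic carbon, the same change as between compound 1 and compound 2, at a place described in the same words. Because compound 1 and compound 2 show a 2.0-fold higher number from compound 1 to compound 2 (0.31 log units; beyond the scatter), compound 4 is expected to show a similar step from compound 3, estimated as a 2.0-fold higher number from compound 3 to compound 4 (0.30 log units; within the scatter). The value for compound 4 in this assay is estimated at 9800 nM, between 5000 nM and 20000 nM.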

Compound 4, half-maximal inhibitory concentration: 6600 nM
Estimate against measurement, compound 4: 1.5-fold (0.17 log units) above; the measured number falls inside the stated range.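

In this assay, iodo in place of isopropyl gives a 1.3-fold higher number from compound 3 to compound 4 (0.13 log units; within the scatter), and this step agrees with the earlier one on the other core: the same change on two cores in this assay, a 2.0-fold higher number (0.31 log units; beyond the scatter) from compound 1 to compound 2 and a 1.3-fold higher number (0.13 log units; within the scatter) from compound 3 to compound 4, 1.5-fold (0.18 log units) apart, within the scatter of two such steps. Pentylamino in place of pentyl gives a 2.0-fold lower number from compound 2 to compound 4 (0.29 log units; within the scatter), and this step also agrees with its earlier counterpart: the same change on two cores in this assay, a 1.3-fold lower number (0.12 log units; within the scatter) from compound 1 to compound 3 and a 2.0-fold lower number (0.29 log units; within the scatter) from compound 2 to compound 4, 1.5-fold (0.18 log units) apart, within the scatter of two such steps. Each change therefore carries between these two cores within the scatter, but four compounds forming one square do not show that either change would keep its size on any other core.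

The compounds shown leave open what a chloro or tert-butyl group would do in place of iodo or isopropyl. They also leave open how a longer chain than pentyl or pentylamino would read.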